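A few compounds are considered here, and "the series" means these few. Any claim that something is new, unique, unknown or untested is made for them only; others in the source may bear on it.

Measured so far in an assay on HEK293 cells for inhibition of N-acylethanolamine-hydrolyzing acid amidase (Rattus norvegicus), read by LC-MS, with a stated time of 30 min; on this read-out lower numbers stand for stronger inhibition and higher numbers for weaker inhibition:

Compound 1, `O=C(CCCCCc1cccc(O)c1)N1CCOC1=O`, gives 8640 nM.
Compound 2, `COc1cccc(CCCCCC(=O)N2CCOC2=O)c1`, gives 16300 nM.
Compound 3, `O=C(CCCCCc1ccc(O)cc1)N1CCOC1=O`, gives 61 nM.

Compound 1 and compound 2 differ by one change, (methyl in place of hydrogen on an oxygen on an aromatic ring), and that change made a step of a 1.9-fold higher number from compound 1 to compound 2 (0.28 log units; within the scatter). Compound 3 carries the same atoms as compound 1 joined differently; the difference between the two cores is not broken down here. Compound 3 stands far lower than both compound 1 and compound 2.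

Compound 4, `COc1ccc(CCCCCC(=O)N2CCOC2=O)cc1`, has not yet been measured. It differs from compound 3 by methyl in place of hydrogen on an oxygen on an aromatic ring, the same change already seen between compound 1 and compound 2, at the same kind of place. Because that earlier change gave a 1.9-fold higher number from compound 1 to compound 2 (0.28 log units; within the scatter), the step from compound 3 to compound 4 is expected to be small as well, about a 2.5-fold higher number from compound 3 to compound 4 (0.39 log units; beyond the scatter). Compound 4 is therefore estimated at 150 nM, most likely between 50 nM and 600 nM.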

Compound 4, half-maximal inhibitory concentration: > 20000 nM
Compound 4 ended at the assay's limit; the forecaster's own chance of this, stated with the estimate: 3%; middle value at least 130-fold (2.12 log units) away from the limit.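

In this assay, hydroxy to methoxy made a step of an at least 320-fold higher number from compound 3 to compound 4 (2.51 log units; beyond the scatter), so the small step seen on one core did not predict the step on the other: the same change on two cores in this assay, a 1.9-fold higher number (0.28 log units; within the scatter) from compound 1 to compound 2 and an at least 320-fold higher number (2.51 log units; beyond the scatter) from compound 3 to compound 4, at least 170-fold (2.24 log units) apart, beyond the scatter of two such steps

The value of compound 4 is a limit of the assay and not a number, so the true size of its step stays unknown: the limit of > 20000 nM in this assay, at which 1 of the 4 values shown sits.

These two pairs show that this change cannot simply be carried from the core of compound 1 to the core of compound 3, but they do not show why, or how it would behave on any other core.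

Still open, from the compounds shown here alone, is whether an amine or a carboxylic acid in place of the hydroxy of compound 3 would keep its strong inhibition. Also open, going by these compounds, is what a longer chain would do.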